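This account rests on a few compounds, and the source may have more. Where it says the series, first, only, none or still open, it means among the compounds named here.

Measured in an in vivo ADME assay on the whole organism (strain Sprague-Dawley) for pharmacokinetics, with Rattus norvegicus as the target; on this read-out lower numbers stand for lower oral bioavailability and higher numbers for higher oral bioavailability:
Compound 1 `COc1cc(C(=O)N2[C@@H](c3nccs3)[C@@H](C(N)=O)C[C@@]2(CC(C)C)C(=O)O)ccc1C(C)(C)C`: 0.6%
Compound 2 `CCOC[C@H]1C[C@@](CC(C)C)(C(=O)O)N(C(=O)c2ccc(C(C)(C)C)c(OC)c2)[C@H]1c1nccs1`: 120%
Compound 3 `COC[C@H]1C[C@@](CC(C)C)(C(=O)O)N(C(=O)c2ccc(C(C)(C)C)c(OC)c2)[C@H]1c1nccs1`: 59%

Compound 1 stands lowest of the three, beyond the scatter from both of the others. Two measured steps replace its carbamoyl on a saturated ring carbon. With ethoxymethyl in its place the result is a number 119.4 percentage points higher from compound 1 to compound 2 (beyond the scatter), and with methoxymethyl it is a number 58.4 percentage points higher from compound 1 to compound 3 (beyond the scatter). A third step, a number 61 percentage points lower from compound 2 to compound 3 (beyond the scatter), places hydrogen in place of methyl on a saturated chain carbon bound to an oxygen on a saturated carbon.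

Compound 4 `CC(C)C[C@@]1(C(=O)O)C[C@H](C(N)=O)[C@H](c2nccs2)N1C(=O)c1ccc(C(C)(C)C)c(Cl)c1` keeps the carbamoyl and changes something else: chloro in place of methoxy on an aromatic carbon. This is chloro in place of methoxy on an aromatic carbon, ortho to a tert-butyl group. None of the three large steps touches that carbon, so the data offer no direct measure of this change. They bear on it only indirectly, since the large steps all involve groups that compound 4 does not alter. Its closest measured relative is compound 1, at 0.6%, and the carbamoyl of that compound remains in place. The expected change is small, a number 2.4 percentage points higher from compound 1 to compound 4 (within the scatter), and is expected to stay within the scatter. The estimated value for compound 4 is 3%, with an expected range from 0.5% to 15%.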

Compound 4, oral bioavailability: 5%
Compound 4: the middle estimate sits 2 percentage points below what was measured, within the range that was stated.
By their numbers in this assay, from the lowest: compounds 1 and 4 (each within the scatter of the next); then compound 3; then compound 2.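

In this assay, chloro in place of methoxy on the aromatic carbon ortho to a tert-butyl group gives a number 4.4 percentage points higher from compound 1 to compound 4 (within the scatter) and so stays within the usual scatter, which means this change at this position leaves no clear mark on the read-out while the carbamoyl remains in place. For the compounds shown here, the earlier steps all concerned other places in the molecule, and the largest of them was a number 119.4 percentage points higher from compound 1 to compound 2 (beyond the scatter) on the same read-out, so this is the first direct reading at the aromatic carbon and it is far smaller than that step. The data at hand offer no measured explanation for this small step.

The compounds shown leave open whether the same change would also stay within the scatter on the ethoxymethyl or methoxymethyl compounds, as this step was read only with the carbamoyl present. They also leave open how an amine, a nitrile or a longer ether chain such as ethoxy would read on this same aromatic carbon.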